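The source may report more compounds than this note shows. Statements on the series, on what has been measured and on what is new or still open speak of the compounds shown alone.

Measured so far:
Compound 1, `C#CCN(Cc1ccc2nc(C)nc(O)c2c1)c1ccc(C(=O)N[C@@H](CCC(=O)O)C(=O)N(C)[C@@H](CCC(=O)O)C(=O)O)cc1`: in an assay on L1210 cells for inhibition of Thymidylate synthase (Mus musculus) (on this read-out lower numbers stand for stronger inhibition and higher numbers for weaker inhibition), compound 1 gives 11 nM.
Compound 2, `C#CCN(Cc1cc2c(O)nc(C)nc2cc1C)c1ccc(C(=O)N[C@@H](CCC(=O)O)C(=O)N(C)[C@@H](CCC(=O)O)C(=O)O)c(F)c1`: in this assay compound 2 gives 1.1 nM.

Compound 2 stands at the lowest number of the two, and its nearest neighbour is compound 1, whose number lies higher, beyond the scatter. Compound 3, `C#CCN(Cc1cc2c(O)nc(C)nc2cc1C)c1ccc(C(=O)N[C@@H](CCC(=O)O)C(=O)N(C)[C@@H](CCC(=O)O)C(=O)O)cc1`, is not yet measured. It differs from compound 2 in one place: hydrogen in place of fluoro on an aromatic carbon. Within the data shown here, no step between two measured compounds isolates this single change, since compound 1 and compound 2 differ from each other in two places at once. The expected step in this assay is therefore a modest loss, with compound 3 sitting between compound 1 and compound 2. The step of a 2.3-fold higher number from compound 2 to compound 3 (0.36 log units; beyond the scatter) is expected to be small but probably beyond the scatter. Compound 3 is estimated at 2.5 nM, with a range from 1 nM to 6 nM.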

Compound 3, inhibition constant: 2.6 nM
Compound 3: middle estimate off by 1.0-fold (0.02 log units), on the low side, within the range that was stated.
By their numbers in this assay, from the lowest: compound 2; then compound 3; then compound 1.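

In this assay, the fluoro on this aromatic carbon now has a step of its own: hydrogen in its place gives a 2.4-fold higher number from compound 2 to compound 3 (0.37 log units; beyond the scatter), a modest change but one beyond the scatter. Compound 3 also isolates the other change, methyl in place of hydrogen on an aromatic carbon, which gives a 4.2-fold lower number from compound 1 to compound 3 (0.63 log units; beyond the scatter), likewise modest and beyond the scatter. The two changes can now be read one at a time, and in both steps the compound carrying the added group has the lower number. Nothing available explains either step.

Among the compounds shown, fluoro appears only together with the methyl, so it remains open whether its step would hold without that methyl. Also open, going by these compounds, is whether chloro or methoxy on the same aromatic carbon would follow fluoro, or whether ethyl would follow methyl.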